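Aziridinyl exchange on the phenyl-bearing quinolinedione core

The source may report more compounds than this note shows. Statements on the series, on what has been measured and on what is new or still open speak of the compounds shown alone.

Two compounds of this series have numbers in a functional assay on NCI60 cells (Homo sapiens) for cytotoxicity; a lower number here means a stronger inhibitor of growth, a higher number a weaker inhibitor of growth. Compound 1 `Cc1ccc2c(n1)C(=O)C=C(N1CC1)C2=O` gives 2040 nM. Within the data shown here, compound 2 `COCCCNC1=CC(=O)c2nc(-c3ccccc3)ccc2C1=O` gives 19100 nM, the highest of the two numbers, and the gap to compound 1 is beyond the scatter; since the two differ in two places, no single-point step between them can be read.

Compound 3 `O=C1C(N2CC2)=CC(=O)c2nc(-c3ccccc3)ccc21` is the next compound to be measured in this assay. It arises from compound 2 by aziridin-1-yl in place of (3-methoxypropyl)amino on a double-bonded ring carbon. Among the measured compounds shown here, no measured pair shows this exact change, so the expected size of the step rests only on the fact that compound 1 also carries aziridin-1-yl and gives 2040 nM. A step toward a lower number, beyond the scatter, is expected from compound 2 to compound 3, a 6.4-fold lower number from compound 2 to compound 3 (0.80 log units; beyond the scatter). Compound 3 is estimated to give 3000 nM in this assay, with a range from 800 nM to 12000 nM.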

Compound 3, concentration for total growth inhibition: 324 nM
The estimate for compound 3 lay 9.3-fold (0.97 log units) above the measured number; the measured number lies below the stated range.
By their numbers in this assay, from the lowest: compound 3; then compound 1; then compound 2.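

In this assay, among these compounds, aziridin-1-yl in place of (3-methoxypropyl)amino on the double-bonded ring carbon gives a 59-fold lower number from compound 2 to compound 3 (1.77 log units; beyond the scatter) and is the first single-point reading of this exchange. With aziridin-1-yl held constant, phenyl in place of methyl on an aromatic carbon gives a 6.3-fold lower number from compound 1 to compound 3 (0.80 log units; beyond the scatter) and is a second, smaller step, so the two places can now be read separately. No measurement on hand speaks to the reason for either step.

Open, as far as these compounds go, is whether the step at the double-bonded ring carbon belongs to aziridin-1-yl itself or would also appear with an azetidine, a pyrrolidine or a shorter amine such as dimethylamino. Equally open, from the compounds shown here alone, is how the aromatic carbon behaves with anything beyond methyl and phenyl, such as a chlorine or a methoxy group.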